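Ring Size on the Ketone Chain and Cell Tolerance

A few compounds are considered here, and "the series" means these few. Any claim that something is new, unique, unknown or untested is made for them only; others in the source may bear on it.

Three compounds of the series have been run in an ADME assay on cells (Homo sapiens) for cytotoxicity (a higher number here means that more compound is tolerated, a lower number that less compound is tolerated), so far. Compound 1 (`O=C1NC2=C(C(=O)OC2)C(c2cccc(O)c2)N1`) gives only the assay limit of > 10000 nM. Compound 2 (`O=C1NC2=C(C(=O)OCC2)C(c2cccc(O)c2)N1`) likewise stops at the limit of > 10000 nM. Compound 3 (`CCC1=C(C(=O)CCC2CCCC2)[C@H](c2ccc(O)c(Cl)c2)NC(=O)N1`) also sits at the limit of > 10000 nM. Within the data shown here, compound 3 therefore stands where every value so far stands: the limit of > 10000 nM in this assay, at which 3 of the 3 values shown sit, with no number resolved for any of the three.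

Compound 4 (`CCC1=C(C(=O)CCC2CCCCCC2)[C@H](c2ccc(O)c(Cl)c2)NC(=O)N1`) is the next to be measured. It differs from compound 3 by cycloheptyl in place of cyclopentyl on a saturated chain carbon, two bonds along the chain from a carbonyl carbon. No step beyond the usual scatter in this assay is expected from this change. Compound 4 is expected to give 20000 nM, with a range of 10000 nM to 60000 nM. The expected step that the limit leaves unreadable from compound 3 to compound 4 is estimated to be none beyond scatter, most likely again a limit.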

Compound 4, half-maximal cytotoxic concentration: > 10000 nM
Compound 4 was reported as a limit (the forecaster's own chance of this, stated with the estimate: 80%); the middle value lies beyond the limit too.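

No step can be read from compound 3 to compound 4, as both stop at a limit: the limit of > 10000 nM in this assay, at which 4 of the 4 values shown sit. The compounds shown leave open whether cycloheptyl and cyclopentyl on this chain differ at all, and no resolved number stands for any compound.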